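Swapping the aryl group on sulfur in compound 3

The compounds below may be only part of what the source reports. "The series", "measured", "known", "first", "only" and "open" are said of these compounds alone.

In a functional assay on DU-145 cells (Homo sapiens) for inhibition, read by trypan blue exclusion, with a stated time of 96 h (a lower number here means a stronger inhibitor of growth, a higher number a weaker inhibitor of growth), compound 3 (`O=C(/C(=C\c1ccc(O)c([N+](=O)[O-])c1)Sc1ccccc1Br)c1ccc(Cl)cc1`) gives 25000 nM, level with compound 1 (`Cc1ccc(S(=O)(=O)/C(=C/c2ccc(O)c([N+](=O)[O-])c2)C(=O)c2ccc(Cl)cc2)cc1`) at 25000 nM, while compound 2 (`O=C(/C(=C\c1ccc(O)c([N+](=O)[O-])c1)SCc1ccccc1Cl)c1ccc(Cl)cc1`) gives 10000 nM. Compound 4 (`Cc1ccc(S/C(=C/c2ccc(O)c([N+](=O)[O-])c2)C(=O)c2ccc(Cl)cc2)cc1`) departs from compound 3 in one place: 4-methylphenyl in place of 2-bromophenyl on a sulfur, with 4-methylphenyl in place of 2-bromophenyl on a sulfur. Among the measured compounds shown here, two measured steps bear on this. Putting (2-bromophenyl)sulfanyl in place of (4-methylphenyl)sulfonyl gave no change at the digits printed from compound 1 to compound 3 (within the scatter), and putting 2-bromophenyl in place of 2-chlorobenzyl on a sulfur gave a 2.5-fold higher number from compound 2 to compound 3 (0.40 log units; beyond the scatter). Neither isolates the new swap, so only a small change is expected in this assay. The estimated move is a 1.3-fold lower number from compound 3 to compound 4 (0.10 log units; within the scatter), not expected to exceed the scatter. Compound 4 is expected at 20000 nM, with an estimated range of 8000 nM to 45000 nM.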

Compound 4, concentration for 50% growth inhibition: 10000 nM
Beside the measured number, compound 4's estimate is 2.0-fold (0.30 log units) above it; the measured number falls inside the stated range.
By their numbers in this assay, from the lowest: compounds 2 and 4 (each within the scatter of the next); then compounds 1 and 3 (each within the scatter of the next).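

In this assay, the group on sulfur matters even with the sulfide link held constant: 4-methylphenyl in place of 2-bromophenyl gives (a 2.5-fold lower number from compound 3 to compound 4 (0.40 log units; beyond the scatter)), and 4-methylphenyl in place of 2-chlorobenzyl gives (no change at the digits printed from compound 2 to compound 4 (within the scatter)). Among the compounds shown here, with 4-methylphenyl held constant, (4-methylphenyl)sulfanyl in place of (4-methylphenyl)sulfonyl isolates the sulfur link for the first time and gives (a 2.5-fold lower number from compound 1 to compound 4 (0.40 log units; beyond the scatter)). No available evidence explains these differences. The compounds shown leave open how an amine or a carboxylic acid on sulfur's aryl group, or a longer chain on sulfur, would fare.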